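The compounds below may be only part of what the source reports. "The series", "measured", "known", "first", "only" and "open" are said of these compounds alone.

Three compounds share one core and differ only in the group attached to an aromatic carbon of the five-membered ring. Compound 1 `Cc1nn(-c2nc(-c3ccc(Cl)c(Cl)c3)c(SC(C)C)s2)c(C(=O)O)c1-c1cncnc1` gives 22000 nM in a functional assay on BJAB cells (Homo sapiens) for antiproliferative activity, with a stated time of 4 days; a higher number here means that more compound is needed for the effect, a lower number that less compound is needed. Compound 2 `Cc1nn(-c2nc(-c3ccc(Cl)c(Cl)c3)c(SC(C)C)s2)c(C(=O)O)c1-c1cnn(C)c1` gives 6800 nM, and compound 3 `Cc1nn(-c2nc(-c3ccc(Cl)c(Cl)c3)c(SC(C)C)s2)c(C(=O)O)c1-c1ccc(Cl)cc1` gives 2500 nM. Compound 3 therefore stands lowest of the three: a 2.7-fold lower number from compound 2 to compound 3 (0.43 log units; beyond the scatter) and an 8.8-fold lower number from compound 1 to compound 3 (0.94 log units; beyond the scatter) both end at it, while a 3.2-fold lower number from compound 1 to compound 2 (0.51 log units; beyond the scatter) separates the other two.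

Compound 4 `Cc1nn(-c2nc(-c3ccc(Cl)c(Cl)c3)c(SC(C)C)s2)c(C(=O)O)c1-c1cccc(C(F)(F)F)c1` carries the series one step further: 3-(trifluoromethyl)phenyl in place of 4-chlorophenyl on an aromatic carbon. Both measured steps that reach compound 3 exchanged pyrimidin-5-yl or 1-methyl-1H-pyrazol-4-yl for 4-chlorophenyl, a ring with nitrogen for a carbon-only ring. Here the ring stays carbon-only and only its substituent changes, so none of the measured steps covers this kind of exchange, and they give little guidance on size or direction. Expected, then, is a 1.2-fold higher number from compound 3 to compound 4 (0.08 log units; within the scatter), a shift near or within the scatter. For compound 4 the estimate is 3000 nM, with a range from 1000 nM to 10000 nM.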

Compound 4, half-maximal effective concentration: 22000 nM
Compound 4: middle estimate off by 7.3-fold (0.87 log units), on the low side, outside the stated range (above it).
By their numbers in this assay, from the lowest: compound 3; then compound 2; then compounds 1 and 4 (each within the scatter of the next).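

In this assay, this position responds to more than the presence or absence of nitrogen in the attached ring: with the ring still carbon-only, 3-(trifluoromethyl)phenyl in place of 4-chlorophenyl gives an 8.8-fold higher number from compound 3 to compound 4 (0.94 log units; beyond the scatter), and in place of 1-methyl-1H-pyrazol-4-yl it gives a 3.2-fold higher number from compound 2 to compound 4 (0.51 log units; beyond the scatter). A carbon-only ring therefore does not by itself bring a lower number, as the comparison with pyrimidin-5-yl shows no change at the digits printed from compound 1 to compound 4 (within the scatter). Nothing available explains why this exchange on the ring has so large an effect.

The compounds shown leave open whether the higher number of compound 4 goes with the trifluoromethyl group itself or with its place on the ring. A 3-chlorophenyl or a 4-(trifluoromethyl)phenyl group at this position would separate these two readings, and a plain phenyl would give a reference for both.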